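A few compounds are considered here, and "the series" means these few. Any claim that something is new, unique, unknown or untested is made for them only; others in the source may bear on it.

In a functional assay on MCF7 cells (Homo sapiens) for antiproliferative activity, read by MTT assay, with a stated time of 24 h (a higher number here means a weaker inhibitor, a lower number a stronger inhibitor), compound 1 (`CCn1c(C(=O)NCCO)ccc1C(CC)(CC)c1ccc(OCS(=O)(=O)c2ccccc2)c(C)c1`) gives 15500 nM and compound 2 (`CCn1c(C(=O)N[C@H](CO)CCCO)ccc1C(CC)(CC)c1ccc(OCS(=O)(=O)c2ccccc2)c(C)c1`) gives 31400 nM as the higher of the two numbers. Compound 3 (`CCn1c(C(=O)N[C@@H](C(=O)O)C(C)C)ccc1C(CC)(CC)c1ccc(OCS(=O)(=O)c2ccccc2)c(C)c1`) departs from compound 2 by a group of 7 heavy atoms (5 carbon, 2 oxygen; no ring) in place of a group of 7 heavy atoms (5 carbon, 2 oxygen; no ring), on an amide-type nitrogen with 1-carboxy-2-methylpropyl entering on an amide-type nitrogen. For the measured compounds named here, the only measured step bearing on this is modest (a 2.0-fold higher number from compound 1 to compound 2 (0.31 log units; beyond the scatter)) and does not involve 1-carboxy-2-methylpropyl, so no step beyond the scatter is expected in this assay in either direction. The expected step is small (a 1.1-fold lower number from compound 2 to compound 3 (0.05 log units; within the scatter)). For compound 3 the estimate is 28000 nM with an expected range from 10000 nM to 75000 nM in these notes.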

Compound 3, half-maximal inhibitory concentration: 44700 nM
Estimate against measurement, compound 3: 1.6-fold (0.20 log units) below, and the stated range covers the measured number.
By their numbers in this assay, from the lowest: compound 1; then compounds 2 and 3 (each within the scatter of the next).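

In this assay, a carboxylic acid on this amide-type nitrogen, as 1-carboxy-2-methylpropyl, is not separated from the group of compound 2 (a 1.4-fold higher number from compound 2 to compound 3 (0.15 log units; within the scatter)). Against 2-hydroxyethyl, the same change gives a step beyond the scatter (a 2.9-fold higher number from compound 1 to compound 3 (0.46 log units; beyond the scatter)), leaving compound 1 with the lowest number of the three. No measurement shown accounts for either step.

The compounds shown leave open whether the carboxylic acid or the branched isopropyl part carries the step from compound 1. They also leave open how an amine or a methyl ester would read at this position.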